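The compounds below may be only part of what the source reports. "The series", "measured", "known", "first", "only" and "open" are said of these compounds alone.

Compound 1 `c1ccc2c(-c3cn4ccnc4c(-c4ccc5ncn(C6CCCCC6)c5c4)n3)cccc2c1` gives 38.9% in a functional assay on HL-60 cells (Homo sapiens) for inhibition, read by sulforhodamine B assay, with a stated time of 48 h, tested at 10 uM; a higher number here means more inhibition at the concentration tested (going by the name of the read-out), a lower number less inhibition. Compound 2 `Brc1ccc(-c2cn3ccnc3c(-c3ccc4ncn(C5CCCCC5)c4c3)n2)cc1` gives 23.2%. Compound 3 `COc1ccccc1-c1cn2ccnc2c(-c2ccc3ncn(C4CCCCC4)c3c2)n1` gives 14.6%.

Compound 3 stands lowest of the three: compound 2 lies within the scatter of it (a number 8.6 percentage points lower from compound 2 to compound 3 (within the scatter)), while compound 1 sits beyond the scatter above it (a number 24.3 percentage points lower from compound 1 to compound 3 (beyond the scatter)). Compound 4 `c1csc(-c2cn3ccnc3c(-c3ccc4ncn(C5CCCCC5)c4c3)n2)c1` differs from compound 3 by thiophen-2-yl in place of 2-methoxyphenyl on an aromatic carbon. Among the measured compounds shown here, the two steps that bear on this position, a number 24.3 percentage points lower from compound 1 to compound 3 (beyond the scatter) and a number 8.6 percentage points lower from compound 2 to compound 3 (within the scatter), were modest or within the scatter, and no measured compound carries a thiophen-2-yl, so the direction is open. A step at most modest in size is expected, a number 5.4 percentage points higher from compound 3 to compound 4 (within the scatter). Compound 4 is therefore estimated at 20%, within a range of 5% to 38%.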

Compound 4, a percentage reported as inhibition, at one concentration (the size of the read-out at that concentration, not a potency): 26.6%
Compound 4: middle estimate off by 6.6 percentage points, on the low side, within the range that was stated.
By their numbers in this assay, from the lowest: compounds 3, 2 and 4 (each within the scatter of the next, the first and the last beyond it); then compound 1.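

In this assay, thiophen-2-yl, with fewer heavy atoms than the groups it replaces, does not sit at the bottom of the series: a number 12 percentage points higher from compound 3 to compound 4 (beyond the scatter), and a number 3.4 percentage points higher from compound 2 to compound 4 (within the scatter). Naphthalen-1-yl keeps the highest number, with a number 12.3 percentage points lower from compound 1 to compound 4 (beyond the scatter). A five-membered aromatic ring with sulfur is therefore accepted at this position about as well as 4-bromophenyl.

No measured evidence accounts for these steps. On these data alone, whether an amine or a carboxylic acid on this aromatic carbon would move the number remains open.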